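Replacing the group on the ring nitrogen of compound 2

The source may report more compounds than this note shows. Statements on the series, on what has been measured and on what is new or still open speak of the compounds shown alone.

In an ADME assay on microsomes from liver (Mus musculus) for metabolic stability, read by LC-MS, using NADPH, with a stated time of 10 min, tested at 0.1 uM (a lower number here means slower removal, a higher number faster removal of the compound), compound 1 `COc1ccc(F)cc1N1C(=O)CSC1c1cccc(C(=O)NCCCCn2cccn2)c1` gives 1310 mL.min-1.g-1 and compound 2 `O=C(NCCCCc1ccccc1)c1cccc(C2SCC(=O)N2c2cccc(-c3c[nH]nn3)c2)c1` gives 951 mL.min-1.g-1 in the same test. These two numbers lie within the scatter of each other, so compound 2 stands level with compound 1, although the two structures differ in more than one place. Compound 3 `O=C(NCCCCc1ccccc1)c1cccc(C2SCC(=O)N2c2ccccc2F)c1` keeps the rest of compound 2 and changes one group on an amide-type nitrogen in a ring (a group of 7 heavy atoms (6 carbon, 1 fluorine; one six-membered aromatic ring of carbon only) in place of a group of 11 heavy atoms (8 carbon, 3 nitrogen; one five-membered aromatic ring with 3 hetero atoms, one six-membered aromatic ring of carbon only), on an amide-type nitrogen in a ring), with 2-fluorophenyl entering. For the measured compounds named here, no measured pair isolates this change, so the expectation rests on little. Going by the values given here, with compound 1 at 1310 mL.min-1.g-1 as the only other number, no step beyond the scatter is expected in this assay here. The estimated step of a 1.3-fold higher number from compound 2 to compound 3 (0.10 log units; within the scatter) is expected to stay within the scatter. For compound 3 the estimate is 1200 mL.min-1.g-1 with an expected range from 600 mL.min-1.g-1 to 2400 mL.min-1.g-1 in repeat measurements.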

Compound 3, intrinsic clearance in microsomes: 2010 mL.min-1.g-1
Estimate against measurement, compound 3: 1.7-fold (0.22 log units) below, and the stated range covers the measured number.
By their numbers in this assay, from the lowest: compounds 2, 1 and 3 (each within the scatter of the next, the first and the last beyond it).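

In this assay, the exchange on the amide-type nitrogen in a ring gives a 2.1-fold higher number from compound 2 to compound 3 (0.33 log units; beyond the scatter) when 2-fluorophenyl enters and the group of 11 heavy atoms leaves. This single-place pair shows that the read-out responds to the group at this position, and that this change goes with faster removal, though the step is modest and only just beyond the scatter. Nothing available here accounts for the step.

The entering and leaving groups differ at once in the five-membered aromatic ring with 3 hetero atoms and in the fluorine, so the pair does not tell which difference carries the step. On these data alone, whether plain phenyl, or a phenyl bearing a carboxylic acid or an amine, on the same nitrogen would follow compound 2 or compound 3 remains open.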